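Moving a methyl from the ring onto the benzylic carbon

The source may report more compounds than this note shows. Statements on the series, on what has been measured and on what is new or still open speak of the compounds shown alone.

Measured compounds:
- compound 1, `Cc1ccccc1CNC(=O)c1nn(-c2ccc(F)cc2)c(OC[C@@H](O)C[C@@H](O)CC(=O)O)c1C(C)C`: 17 nM
- compound 2, `Cc1cccc(CN(C)C(=O)c2nn(-c3ccc(F)cc3)c(OC[C@@H](O)C[C@@H](O)CC(=O)O)c2C(C)C)c1`: 37 nM

Among the compounds with values here, in an assay on microsomes from liver for inhibition of 3-hydroxy-3-methylglutaryl-coenzyme A reductase (Rattus norvegicus) (on this read-out higher numbers stand for weaker inhibition and lower numbers for stronger inhibition), compound 2 gives 37 nM, the higher of the two numbers known so far; its only neighbour is compound 1, which in this assay gives 17 nM. Within the data shown here, the one step between measured compounds is a 2.2-fold higher number from compound 1 to compound 2 (0.34 log units; beyond the scatter), a modest weakening that bundles two alterations at once: the methyl on the nitrogen appears and the ring methyl shifts.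

Compound 3, `CC(C)c1c(C(=O)N(C)[C@H](C)c2ccccc2)nn(-c2ccc(F)cc2)c1OC[C@@H](O)C[C@@H](O)CC(=O)O`, is built from compound 2 by 1-phenylethyl in place of 3-methylbenzyl on an amide-type nitrogen. The ring methyl of compound 2 is thus gone, and a methyl now sits on the carbon that joins the phenyl ring to the amide nitrogen, with a defined stereocentre. Among the measured compounds shown here, no measured step isolates this kind of rearrangement, so the step from compound 1 to compound 2 bears on it only loosely, as a sign that small changes around this amide have so far produced modest effects. The expected step is therefore a 1.2-fold lower number from compound 2 to compound 3 (0.09 log units; within the scatter), most likely not beyond the scatter. Compound 3 is estimated at 30 nM, within 10 nM to 90 nM.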

Compound 3, half-maximal inhibitory concentration: 21 nM
Estimate against measurement, compound 3: 1.4-fold (0.15 log units) above; measured number inside the range.
By their numbers in this assay, from the lowest: compounds 1, 3 and 2 (each within the scatter of the next, the first and the last beyond it).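

Swapping 3-methylbenzyl for 1-phenylethyl on the amide-type nitrogen keeps the same atoms and adds one defined stereocentre, and the swap gives a 1.8-fold lower number from compound 2 to compound 3 (0.25 log units; within the scatter). The two groups therefore cannot be told apart on these numbers, so this rearrangement of the same eight carbons, with its stereocentre, carries no measurable penalty or gain here. The comparison with the compound whose amide nitrogen has no methyl is new and gives a 1.2-fold higher number from compound 1 to compound 3 (0.09 log units; within the scatter), which shows that a methyl on this nitrogen does not always come with a weakening beyond the scatter, as the bundled earlier step might have suggested, although nothing on hand explains why these numbers lie so close.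

The single stereocentre leaves open how the mirror-image form of 1-phenylethyl would read, and so whether the arrangement at that carbon matters at all. Also open, as far as these compounds go, is whether this position would accept something larger or different in kind, such as 1-phenylpropyl with its longer chain, or a benzyl group carrying a carboxylic acid on its ring.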